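The source may report more compounds than this note shows. Statements on the series, on what has been measured and on what is new or still open speak of the compounds shown alone.

In a functional assay on MAC16 cells (Mus musculus) for antiproliferative activity, read by MTT assay, with a stated time of 3 days (a lower number here means a stronger inhibitor, a higher number a weaker inhibitor), compound 1 (`CC(C)CN1C(=O)C=C(Cl)C1(O)c1ccccc1`) gives 96 nM and compound 2 (`CC(C)CN1C(=O)C=C(Cl)C1(O)c1ccc(Cl)cc1`) gives 86 nM and the two lie within the scatter of each other. The change to compound 3 (`O=C1C=C(Cl)C(O)(c2ccccc2)N1Cc1ccccc1`) is phenyl in place of isopropyl on a saturated chain carbon bound to an amide-type nitrogen in a ring and in words it is phenyl in place of isopropyl on a saturated chain carbon bound to an amide-type nitrogen in a ring, or isobutyl to benzyl when cut one bond further out. Among the compounds with values here, the one measured step is a 1.1-fold lower number from compound 1 to compound 2 (0.05 log units; within the scatter) for chloro in place of hydrogen on an aromatic carbon. That is a different place, so it bears on this change only loosely. Within the data shown here, no measured pair varies this chain and the data give no direction, so no step beyond the scatter is expected in this assay and the uncertainty stays wide. The expected step is a 1.1-fold lower number from compound 1 to compound 3 (0.03 log units; within the scatter) and it remains an estimate. For compound 3 the estimate is 90 nM with 30 nM and 270 nM as the expected ends of the range.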

Compound 3, half-maximal inhibitory concentration: > 1000 nM
Compound 3 gave a limit, no number; the forecaster's own chance of this, stated with the estimate: 3%; at least 11-fold (1.04 log units) between middle value and limit.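

Compound 3 reads > 1000 nM in this assay, which is a limit and not a number. Phenyl in place of isopropyl on a saturated chain carbon bound to an amide-type nitrogen in a ring gives an at least 10-fold higher number from compound 1 to compound 3 (1.01 log units; beyond the scatter), so the group at this place is not indifferent in this assay. Within the data shown here, the only earlier step, a 1.1-fold lower number from compound 1 to compound 2 (0.05 log units; within the scatter), lay within the scatter and involved a different place, so this is the first step beyond the scatter.

From the compounds shown here alone, whether the step goes with the aromatic ring of benzyl or with any group larger than isobutyl stays open: a cyclohexylmethyl group or a longer alkyl chain would separate the two. Also open, going by these compounds, is whether a benzyl carrying an amine or a carboxylic acid on its ring would read differently from compound 3.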